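The compounds below may be only part of what the source reports. "The series", "measured", "known", "first", "only" and "open" are said of these compounds alone.

Of the compounds shown here, three have so far been tested in a functional assay on HCT-116 cells (Homo sapiens) for inhibition, read by CCK-8 assay, with a stated time of 48 h; on this read-out higher numbers stand for weaker inhibition and lower numbers for stronger inhibition. Compound 1 `COc1ccc(CN(C(=O)CSC(=S)N2CCc3cc(OC)ccc32)c2cc(OC)c(OC)c(OC)c2)cc1` gives 9810 nM in this test. Compound 2 `COc1ccc(CN(C(=O)CSC(=S)N2CCN(C(=O)OC(C)(C)C)CC2)c2ccc(Br)cc2)cc1` is reported only as a limit, > 20000 nM, and not as a number. Compound 3 `COc1cc(N(Cc2ccc(Cl)cc2)C(=O)CSC(=S)N2CCN(C(=O)OC(C)(C)C)CC2)cc(OC)c1OC` gives 8490 nM, which lies within the usual scatter of the number for compound 1, so the two cannot be told apart here. Compound 3 therefore stands level with compound 1 among the numbers in hand.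

Compound 4 `COc1ccc(CN(C(=O)CSC(=S)N2CCN(C(=O)OC(C)(C)C)CC2)c2cc(OC)c(OC)c(OC)c2)cc1Br` has yet to be measured in this assay. It carries 3-bromo-4-methoxyphenyl in place of 4-chlorophenyl on a saturated chain carbon bound to an amide-type nitrogen. Within the data shown here, no two measured compounds differ in one place only, so the data offer no direct measure of such a change. The numbers for compound 1 at 9810 nM and compound 3 at 8490 nM sit close together despite their different structures, which gives no reason to expect a large shift. The expected change, a 1.2-fold higher number from compound 3 to compound 4 (0.07 log units; within the scatter), is none beyond the scatter. For compound 4 the estimated value is 10000 nM, with an expected range from 4500 nM to 20000 nM.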

Compound 4, half-maximal inhibitory concentration: 9710 nM
Compound 4: middle estimate off by 1.0-fold (0.01 log units), on the high side, and the stated range covers the measured number.
By their numbers in this assay, from the lowest: compounds 3, 4 and 1 (each within the scatter of the next). At a limit, above all of these: compound 2.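

The replacement of 4-chlorobenzyl by 3-bromo-4-methoxybenzyl, on a saturated chain carbon bound to an amide-type nitrogen, gives in this assay a 1.1-fold higher number from compound 3 to compound 4 (0.06 log units; within the scatter). Among these compounds, this is the first direct reading at this position, since the earlier compounds offered no pair differing in one place only. The entering group has more heavy atoms and a hydrogen-bond acceptor that the leaving group lacks, yet the two numbers cannot be told apart in this test, so for this one pair, with the rest of the structure held fixed, the position takes either group without a measurable difference.

On these data alone, what an amine or a carboxylic acid on the aromatic ring at this position would give stays open, as does the outcome of a longer chain in place of the benzyl group, and one pair cannot show whether the same replacement would read alike on the core of compound 1. Compound 2 is reported only as a limit and not as a number, so it gives no size for any step: the limit of > 20000 nM in this assay, at which 1 of the 4 values shown sits.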